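Isopropyl amide on the carbamate analogue

The source may report more compounds than this note shows. Statements on the series, on what has been measured and on what is new or still open speak of the compounds shown alone.

Of the compounds shown here, three of a shared core have been measured in a functional assay on HEK293 cells for agonist activity at Glucose-dependent insulinotropic receptor (Homo sapiens), read by HTRF and cAMP accumulation, with a stated time of 30 min; a lower number here means that less compound is needed, a higher number that more compound is needed for the effect. Compound 1 `CCNC(=O)c1cc(F)c(-c2cc3nnn(C4CCN(c5ncc(CC)cn5)CC4)c3cn2)cc1F` gives 2 nM, compound 2 `CCNC(=O)c1ccc(-c2cc3nnn(C4CCN(c5ncc(CC)cn5)CC4)c3cn2)c(Cl)c1` gives 13 nM, and compound 3 `CCNC(=O)c1cc(F)c(-c2cc3nnn(C4CCN(C(=O)OC(C)C)CC4)c3cn2)cc1F` gives 37 nM. Within the data shown here, compound 3 thus stands at the highest number of the three, with compound 2 nearest to it and compound 1 furthest away; the only single-point step that reaches it is a 19-fold higher number from compound 1 to compound 3 (1.27 log units; beyond the scatter), a large rise in this assay.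

Compound 4 `CC(C)NC(=O)c1cc(F)c(-c2cc3nnn(C4CCN(C(=O)OC(C)C)CC4)c3cn2)cc1F` differs from compound 3 only at the amide end: methyl in place of hydrogen on a saturated chain carbon bound to an amide-type nitrogen and a saturated chain carbon. Among the measured compounds shown here, none of the measured steps touches this amide substituent; the one step that involves compound 3 changes the group on the amine nitrogen in the ring, not the amide, so nothing measured bears directly on the change from compound 3 to compound 4. In the absence of any such precedent, the author expects the step to be small, within or close to the scatter in this assay, with no clear direction. The estimated value for compound 4 in this assay is therefore 40 nM, expected to lie between 15 nM and 120 nM, which corresponds to an expected step of a 1.1-fold higher number from compound 3 to compound 4 (0.03 log units; within the scatter).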

Compound 4, half-maximal effective concentration: 33 nM
Compound 4: middle estimate off by 1.2-fold (0.08 log units), on the high side, within the range that was stated.
By their numbers in this assay, from the lowest: compound 1; then compound 2; then compounds 4 and 3 (each within the scatter of the next).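

Read in this assay, the change from ethylcarbamoyl to isopropylcarbamoyl gives a 1.1-fold lower number from compound 3 to compound 4 (0.05 log units; within the scatter), the first measured step at this amide substituent, and it shows that one added methyl on the saturated chain carbon bound to the amide-type nitrogen produces no difference that can be told from the scatter on this carbamate-bearing analogue. This stands in contrast to the only earlier step within this series, a 19-fold higher number from compound 1 to compound 3 (1.27 log units; beyond the scatter), which lies at the group on the amine nitrogen in the ring and is large, so among the steps shown, only the change at that ring nitrogen moves the number beyond the scatter. No supporting evidence bears on this result, and the reason for it remains unknown.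

The compounds shown leave open whether ethyl to isopropyl reads the same with 5-ethylpyrimidin-2-yl on the ring nitrogen, where compound 1 gives 2 nM and any difference would start from a much lower number. Also open, going by these compounds, is how far this amide substituent can be taken, for instance to a tert-butyl group, a longer chain or a chain ending in an amine.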